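The source may report more compounds than this note shows. Statements on the series, on what has been measured and on what is new or still open speak of the compounds shown alone.

Measured in an ADME assay on microsomes from liver (Homo sapiens) for pharmacokinetics; on this read-out higher numbers stand for fast clearance and lower numbers for slow clearance:
- compound 1 `Cc1nn(C2COC2)cc1Nc1nc(N)c2c(C#N)c(N3CCC[C@H]3C)n(C)c2n1`: 46.7 mL/min/kg
- compound 2 `Cc1c(Nc2nc(N)c3c(C#N)c(N4CCC[C@H]4C)n(C)c3n2)cnn1[C@H]1CCOC1`: 23.3 mL/min/kg
- compound 3 `C[C@@H]1CCCN1c1c(C#N)c2c(N)nc(Nc3cn(C)nc3Cl)nc2n1C`: 183 mL/min/kg

Compound 2 sits within the scatter of compound 1 and, beyond the scatter, under compound 3. Compound 4 `Cc1c(Nc2nc(N)c3c(C#N)c(N4CCC[C@H]4C)n(C)c3n2)cnn1[C@@H]1CCOC1` departs from compound 2 as follows: the two compounds have the same atoms and bonds and differ only in configuration as drawn: 1 of 2 stereo elements differ; a stereocentre at a saturated ring carbon is drawn S in compound 2 and R in compound 4. Among the compounds with values here, the one measured step, a 3.9-fold higher number from compound 1 to compound 3 (0.59 log units; beyond the scatter), exchanges atoms, whereas here the atoms and bonds stay the same, so it does not measure this change. Within the data shown here, no measured pair isolates configuration at this stereocentre. No step beyond the scatter is therefore expected in this assay, and no direction can be given. The estimated step is a 1.1-fold higher number from compound 2 to compound 4 (0.03 log units; within the scatter). For compound 4 the expected value is 25 mL/min/kg, with an estimated range from 11 mL/min/kg to 55 mL/min/kg.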

Compound 4, clearance: 28.3 mL/min/kg
Estimate against measurement, compound 4: 1.1-fold (0.05 log units) below, within the range that was stated.
By their numbers in this assay, from the lowest: compounds 2, 4 and 1 (each within the scatter of the next); then compound 3.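

In this assay, the change from S to R at the saturated ring carbon gives a 1.2-fold higher number from compound 2 to compound 4 (0.08 log units; within the scatter), so the two drawn configurations are not separated on this read-out. Within the data shown here, this is the first direct reading at this stereocentre, and it rests on a single pair: the fact that compounds 2 and 4 differ only in the configuration as drawn.

The second stereocentre, drawn the same in both compounds, remains unread. Going by these compounds, whether an amine or a carboxylic acid on the same saturated ring would leave this assay equally insensitive to configuration also remains open.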